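This account rests on a few compounds, and the source may have more. Where it says the series, first, only, none or still open, it means among the compounds named here.

Measured compounds:

- compound 1 `Cc1ccc(N2CCN(C(=S)SCc3ccc(C(=O)Nc4ccccc4N)cc3)CC2)cc1` — 33.4%
- compound 2 `CN1CCN(C(=S)SCc2ccc(C(=O)Nc3ccccc3N)cc2)CC1` — 29.6%
- compound 3 `Nc1ccccc1NC(=O)c1ccc(CSC(=S)N2CCN(c3ccncc3)CC2)cc1` — 64.8%

In a functional assay on MGC-803 cells (Homo sapiens) for antiproliferative activity, read by CCK-8 assay, with a stated time of 72 h, tested at 2 uM (on this read-out lower numbers stand for a weaker effect and higher numbers for a stronger effect at the one concentration tested), compound 3 gives the highest number of the three, and its steps to the other two are both beyond the scatter. The step of a number 31.4 percentage points higher from compound 1 to compound 3 (beyond the scatter) and the step of a number 35.2 percentage points higher from compound 2 to compound 3 (beyond the scatter) each came with a change of the group on an amine nitrogen in a ring, and both are large; the step of a number 3.8 percentage points lower from compound 1 to compound 2 (within the scatter), by contrast, stayed within the scatter.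

Compound 4 `Nc1ccccc1NC(=O)c1ccc(CSC(=S)N2CCN(c3cnccn3)CC2)cc1` differs from compound 3 in one place: pyrazin-2-yl in place of pyridin-4-yl on an amine nitrogen in a ring. None of the three measured steps covers this kind of exchange, since each of them moved between methyl, 4-methylphenyl and pyridin-4-yl rather than between two aromatic rings that both carry ring nitrogen. What can be said is that this position has shown large effects in this assay, so a sizeable move in either direction cannot be excluded. With compound 3 as the only close reference, compound 4 is expected to land near it, with a step of about a number 9.8 percentage points lower from compound 3 to compound 4 (within the scatter) in this assay. The estimate for compound 4 is therefore 55%, within a range from 35% to 75%.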

Compound 4, a percentage reported as inhibition, at one concentration (the size of the read-out at that concentration, not a potency): 27.1%
The estimate for compound 4 lay 27.9 percentage points above the measured number; the whole stated range lies above it.
By their numbers in this assay, from the lowest: compounds 4, 2 and 1 (each within the scatter of the next); then compound 3.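

In this assay, an exchange of one aromatic ring for another on this amine nitrogen in a ring proves as consequential as the earlier exchanges: a number 37.7 percentage points lower from compound 3 to compound 4 (beyond the scatter) came with pyrazin-2-yl in place of pyridin-4-yl. These two six-membered aromatic rings have the same number of heavy atoms, and the entering one simply has 2 hetero atoms where the leaving one has 1, so a small change in the ring can be enough to separate two compounds here. The other new steps, a number 2.5 percentage points lower from compound 2 to compound 4 (within the scatter) and a number 6.3 percentage points lower from compound 1 to compound 4 (within the scatter), leave pyrazin-2-yl level with methyl and 4-methylphenyl, so a ring nitrogen alone does not set a compound apart, and among these four compounds only the pyridin-4-yl compound, compound 3, stands out. Nothing measured here explains why these two rings behave so differently.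

The compounds shown leave open how pyridin-3-yl, pyrimidin-5-yl or a plain phenyl ring would score on this same nitrogen. They also leave open whether the gap between compound 3 and compound 4 would persist at other concentrations or in other cell lines.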